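Phenyl to 3,5-Dimethyl-1,2-oxazol-4-yl: an Expected Antiproliferative Outcome

A few compounds are considered here, and "the series" means these few. Any claim that something is new, unique, unknown or untested is made for them only; others in the source may bear on it.

Compound 1, `CCc1c(C)[nH]c2cc(OCCOc3ccccc3)c(OC)cc2c1=O`: > 29000 nM in an ADME assay on J774 cells (Mus musculus) for antiproliferative activity, with a stated time of 72 h (on this read-out higher numbers stand for an effect only at larger amounts of compound and lower numbers for an effect already at smaller amounts), a limit.
Compound 2, `CCCCc1cc2c(=O)c(-c3ccccc3)c(C)[nH]c2cc1OCCOc1ccccc1`: 23000 nM in this assay.

Of the compounds shown here, two have been measured. Compound 1 gives only > 29000 nM in this assay, which is a limit of the assay and not a number. Compound 2 gives 23000 nM in this assay. Going by the values given here, compound 2 therefore stands on the only true number in the set, since the other value is the limit of > 29000 nM in this assay, at which 1 of the 2 values shown sits.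

Compound 3, `CCCCc1cc2c(=O)c(-c3c(C)noc3C)c(C)[nH]c2cc1OCCOc1ccccc1`, is not yet measured. It differs from compound 2 in one place: 3,5-dimethyl-1,2-oxazol-4-yl in place of phenyl on an aromatic carbon. Among the compounds with values here, no measured pair in the set shares this change, so there is no direct step to lean on. The expectation for compound 3 is a step of about a 1.1-fold higher number from compound 2 to compound 3 (0.04 log units; within the scatter) in this assay, no clear movement in either direction. Compound 3 is thus estimated at 25000 nM, with a range from 10000 nM to 60000 nM.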

Compound 3, half-maximal effective concentration: 22000 nM
For compound 3 the middle estimate is 1.1-fold (0.06 log units) above the measured one; the range from low to high includes it.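

In this assay, going by these compounds alone, the change to 3,5-dimethyl-1,2-oxazol-4-yl gives a 1.0-fold lower number from compound 2 to compound 3 (0.02 log units; within the scatter), so the only measured step at this position shows no clear movement. On this aromatic carbon, two atoms from the ring nitrogen, a five-membered aromatic ring with 2 hetero atoms and 2 hydrogen-bond acceptors takes the place of phenyl, and the read-out stays within the scatter. Compound 1 remains the one compound given only as a limit of the assay, not as a number: the limit of > 29000 nM in this assay, at which 1 of the 3 values shown sits.

The compounds shown leave open whether any group on this carbon would move the number clearly, for instance an amine or a carboxylic acid in place of the phenyl of compound 2. A single step also cannot tell whether the same flat result would hold on the core with a chain other than butyl.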